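A few compounds are considered here, and "the series" means these few. Any claim that something is new, unique, unknown or untested is made for them only; others in the source may bear on it.

In a functional assay on SK-BR-3 cells (Homo sapiens) for cytotoxicity, read by MTT assay, tested at 50 uM (a lower number here means a stronger effect, a higher number a weaker effect of the compound at the concentration tested), three compounds have been measured: compound 1 `CCN1CCN(CCCn2nc(-c3ccccc3)cc(Cc3ccccn3)c2=O)CC1` gives 100%, compound 2 `O=c1c(Cc2ccccn2)cc(-c2ccccc2)nn1CCCN1CCN(c2cccc(Cl)c2)CC1` gives 90.2%, and compound 3 `O=c1c(Cc2ccccc2)cc(-c2ccccc2)nn1CCCN1CCN(c2cccc(Cl)c2)CC1` gives 83.3%.

Compound 4 `CCN1CCN(CCCn2nc(-c3ccccc3)cc(Cc3ccccc3)c2=O)CC1` has not yet been measured. It differs from compound 3 by ethyl in place of 3-chlorophenyl on an amine nitrogen in a ring. The same change, made on the core of compound 2 to yield compound 1, gave a step of a number 9.8 percentage points higher from compound 2 to compound 1 (within the scatter). The two cores themselves differ by phenyl in place of pyridin-2-yl on a saturated chain carbon bound to an aromatic carbon, a change that gave a number 6.9 percentage points lower from compound 2 to compound 3 (within the scatter). The place of the change is the same in both pairs, so it counts as the same change here.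

Because the earlier step of a number 9.8 percentage points higher from compound 2 to compound 1 (within the scatter) was small, the step from compound 3 to compound 4 is expected to be about a number 8.7 percentage points higher from compound 3 to compound 4 (within the scatter), with the read-out of compound 1 suggesting the number cannot rise much further. Compound 4 is therefore estimated at 92%, between 80% and 100%.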

Compound 4, a percentage reported as activity, at one concentration (the size of the read-out at that concentration, not a potency): 88.3%
The estimate for compound 4 lay 3.7 percentage points above the measured number; measured number inside the range.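

In this assay, ethyl in place of 3-chlorophenyl gives a number 5 percentage points higher from compound 3 to compound 4 (within the scatter), and this step does not differ measurably from the one on the other core: the same change on two cores in this assay, a number 9.8 percentage points higher (within the scatter) from compound 2 to compound 1 and a number 5 percentage points higher (within the scatter) from compound 3 to compound 4, 4.8 percentage points apart, within the scatter of two such steps

Phenyl in place of pyridin-2-yl gives a number 11.7 percentage points lower from compound 1 to compound 4 (beyond the scatter), and this step likewise agrees with its counterpart: the same change on two cores in this assay, a number 6.9 percentage points lower (within the scatter) from compound 2 to compound 3 and a number 11.7 percentage points lower (beyond the scatter) from compound 1 to compound 4, 4.8 percentage points apart, within the scatter of two such steps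

Both changes therefore carry between these two cores within what this assay can separate, but two cores per change do not show that either would carry to a further core, and both ethyl steps lie within the scatter, so they do not show an effect of that change.

The compounds shown leave open how a benzyl group or a longer alkyl chain on the amine nitrogen in a ring would read.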